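This account rests on a few compounds, and the source may have more. Where it says the series, first, only, none or still open, it means among the compounds named here.

Going by the values given here, compound 1 `Clc1ccc(-c2cc(-c3ccsc3)nc(-c3ccccc3Cl)c2)o1` gives 19300 nM in a functional assay on DU-145 cells (Homo sapiens) for cytotoxicity, in the presence of a further agent that is not named here (a lower number here means a stronger inhibitor, a higher number a weaker inhibitor), and stands at the highest of the three numbers so far, though every gap to the others lies within the scatter. Among the compounds with values here, compound 2 `Clc1ccc(-c2cc(-c3cccs3)nc(-c3ccccc3Cl)c2)o1` gives 16800 nM in this assay, and the one single-point step between measured compounds, a 1.1-fold lower number from compound 1 to compound 2 (0.06 log units; within the scatter), changes nothing beyond the scatter. Compound 3 `Cc1ccc(-c2cc(-c3ccoc3)cc(-c3ccsc3)n2)cc1` gives 13000 nM in this assay, a value within the scatter of that of compound 1.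

Compound 4 `Clc1ccc(-c2cc(-c3ccsc3)nc(-c3ccccn3)c2)o1` carries pyridin-2-yl in place of 2-chlorophenyl on an aromatic carbon. Within the data shown here, no measured step touches that position; the one step in hand concerns the thiophene and is itself flat. Compound 4 is therefore expected to stay close to compound 1, a 1.0-fold lower number from compound 1 to compound 4 (0.01 log units; within the scatter), with an estimated 19000 nM in this assay and a range of 8000 nM to 45000 nM.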

Compound 4, half-maximal inhibitory concentration: 10900 nM
Compound 4: the middle estimate sits 1.7-fold (0.24 log units) above what was measured; measured number inside the range.
By their numbers in this assay, from the lowest: compounds 4, 3, 2 and 1 (each within the scatter of the next).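

Placing pyridin-2-yl in place of 2-chlorophenyl next to the ring nitrogen gives a 1.8-fold lower number from compound 1 to compound 4 (0.25 log units; within the scatter) in this assay. This position therefore accepts a six-membered aromatic ring with a hetero atom and a hydrogen-bond acceptor, without chlorine, and the number stays within the scatter. Nothing available explains this result.

From the compounds shown here alone, it remains open whether an amine or a carboxylic acid at this position would move the number beyond the scatter. Also open, going by these compounds, is what replacing the 5-chlorofuran-2-yl group with a morpholine would do.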